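The source may report more compounds than this note shows. Statements on the series, on what has been measured and on what is new or still open speak of the compounds shown alone.

Measured so far in an in vitro assay on SH-SY5Y cells for displacement of a labelled ligand from Neuronal acetylcholine receptor; alpha3/beta4 (Homo sapiens); a lower number here means a stronger inhibitor, a higher number a weaker inhibitor:
- compound 1 `COc1cc(C2=CC3CC(C2)CN(C)C3)cnc1Cl`: 1430 nM
- compound 2 `CN1CC2C=C(c3ccc(F)nc3)CC(C2)C1`: 1310 nM

Compound 2 holds the lowest of the two numbers in this assay, and the nearest is compound 1, a gap that lies within the scatter of repeated measurements, so the two compounds are not separated by the data. Among the compounds with values here, compound 1 and compound 2 differ in more than one place, so no single structural step between them can be read out of the pair.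

Compound 3 `CN1CC2C=C(c3ccc(Cl)nc3)CC(C2)C1` has not yet been measured in this assay. It differs from compound 2 by chloro in place of fluoro on an aromatic carbon. Within the data shown here, no step between measured compounds bears on such a halogen exchange, so the series itself gives no size for it. The change is a single heavy atom swapped for a single heavy atom on the same aromatic carbon, and the working expectation is a step from compound 2 to compound 3 of a 1.3-fold lower number from compound 2 to compound 3 (0.12 log units; within the scatter), a small move toward a lower number that stays within the scatter. For compound 3 the estimate in this assay is 1000 nM, with a range from 400 nM to 2500 nM.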

Compound 3, inhibition constant: 986 nM
Beside the measured number, compound 3's estimate is 1.0-fold (0.01 log units) above it; measured number inside the range.
By their numbers in this assay, from the lowest: compounds 3, 2 and 1 (each within the scatter of the next).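

The halogen position next to the ring nitrogen and para to a large group now has its first direct comparison: in this assay, chloro in place of fluoro gives a 1.3-fold lower number from compound 2 to compound 3 (0.12 log units; within the scatter), so the data do not separate these two halogens at this aromatic carbon. A second place on the same aromatic ring can also be read, with the chloro kept: hydrogen in place of methoxy gives a 1.5-fold lower number from compound 1 to compound 3 (0.16 log units; within the scatter), so the methoxy group of compound 1 is not separated from hydrogen either. Neither single change moves the number beyond the scatter, and no measurement at hand accounts for either result.

The compounds shown leave open whether any group on the carbon next to the ring nitrogen can produce a step beyond the scatter, for instance an amine, a nitrile or a methoxy group in place of the halogen. They also leave open whether the methoxy-to-hydrogen step would read the same with fluoro in place of chloro on the ring.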